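The source may hold more compounds than are shown below. What is called first, only, known or untested is meant among the compounds shown, and "the series" means these compounds.

Working notes on the stilbene sulfonamide series. In a functional assay on CAKI-1 cells (Homo sapiens) for inhibition (on this read-out lower numbers stand for stronger inhibition of growth and higher numbers for weaker inhibition of growth), compound 2 `COc1cccc(/C=C/c2ccc(S(N)(=O)=O)cc2)c1` gives 14700 nM, the low end of the three numbers recorded so far. Compound 1 `COc1cc(/C=C/c2ccc(S(N)(=O)=O)cc2)cc(OC)c1` gives 19000 nM, and the step of a 1.3-fold lower number from compound 1 to compound 2 (0.11 log units; within the scatter) sits within the scatter. Compound 3 `NS(=O)(=O)c1ccc(/C=C/c2ccc(F)cc2)cc1` gives 36300 nM, a gap from compound 2 that lies beyond the scatter. Compound 4 `NS(=O)(=O)c1ccc(/C=C/c2cccc(O)c2)cc1` differs from compound 2 by hydrogen in place of methyl on an oxygen on an aromatic ring. Within the data shown here, the only measured step that bears on it is the removal of a methoxy, from compound 1 to compound 2, which stayed within the scatter; no step touches the oxygen itself. No step beyond the scatter is therefore expected in this assay, in either direction. Compound 4 is expected to give 15000 nM (range 7000 nM to 32000 nM), a step of a 1.0-fold higher number from compound 2 to compound 4 (0.01 log units; within the scatter).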

Compound 4, concentration for 50% growth inhibition: 50200 nM
For compound 4 the middle estimate is 3.3-fold (0.52 log units) below the measured one, outside the stated range (above it).
By their numbers in this assay, from the lowest: compounds 2, 1, 3 and 4 (each within the scatter of the next, the first and the last beyond it).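

In this assay, among these compounds, the group on this oxygen matters: the methoxy to hydroxy change is a 3.4-fold higher number from compound 2 to compound 4 (0.53 log units; beyond the scatter) and so reaches past what the earlier compounds showed, where the one step available, a 1.3-fold lower number from compound 1 to compound 2 (0.11 log units; within the scatter), stayed small. Losing a whole methoxy from compound 1 left the number in place, whereas losing only the methyl from the methoxy of compound 2 raised it. No evidence at hand bears on this result.

Open, on these data alone, is whether a longer chain on the oxygen, such as ethoxy, would stay with compound 2 or move with compound 4. As far as these compounds go, an amine in place of the hydroxy is equally open.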